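Three Limits of Tolerance and a Cyclic Ether Newcomer

A few compounds are considered here, and "the series" means these few. Any claim that something is new, unique, unknown or untested is made for them only; others in the source may bear on it.

Compound 1 `CCCCCNc1cc(Oc2c(OC)cc3cc(C#N)ccc3c2OC)nc(Nc2ccc(C#N)cc2)n1`: in an ADME assay on MT4 cells (Homo sapiens) for cytotoxicity, read by MTT assay, with a stated time of 5 days (a lower number here means that less compound is tolerated, a higher number that more compound is tolerated), compound 1 gives > 125000 nM, which is a limit of the assay rather than a number.
Compound 2 `CCCCCC(C)Nc1cc(Oc2c(OC)cc3cc(C#N)ccc3c2OC)nc(Nc2ccc(C#N)cc2)n1`: compound 2 gives > 125000 nM, again only a limit.
Compound 3 `COc1cc2cc(C#N)ccc2c(OC)c1Oc1cc(NC2CCCCC2)nc(Nc2ccc(C#N)cc2)n1`: compound 3 gives > 125000 nM, also a limit.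

Compound 2 therefore stands at the same limit as its two neighbours, the point at which every value here sits (the limit of > 125000 nM in this assay, at which 3 of the 3 values shown sit). None of the three steps between the measured compounds can be read: a step that the two limits leave unreadable from compound 1 to compound 2, a step that the two limits leave unreadable from compound 1 to compound 3 and a step that the two limits leave unreadable from compound 2 to compound 3 are all hidden by the limit on both sides.

The new member is compound 4 `COc1cc2cc(C#N)ccc2c(OC)c1Oc1cc(NCC2CCOC2)nc(Nc2ccc(C#N)cc2)n1`. The change from compound 2 is (oxolan-3-yl)methyl in place of 1-methylhexyl on a nitrogen on an aromatic ring. Among the measured compounds shown here, the steps that bear on it are the three above, each of which swaps the group on that same nitrogen and each of which ends at the limit. Because all three values shown sit at the limit (the limit of > 125000 nM in this assay, at which 3 of the 3 values shown sit), compound 4 is expected to show no step beyond the scatter, written as a step that the limit leaves unreadable from compound 2 to compound 4. The estimate for compound 4 in this assay is accordingly 150000 nM, with a range from 60000 nM to 400000 nM, and most likely the assay will again report only its limit.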

Compound 4, half-maximal cytotoxic concentration: > 125000 nM
Compound 4: a limit, no number (the forecaster's own chance of this, stated with the estimate: 85%); the middle value lies beyond the limit too.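

In this assay compound 4 gives > 125000 nM as a limit of the assay and not a number. The steps from compound 1, compound 2 and compound 3 to compound 4 therefore cannot be read, since all four compounds stand at the same point: the limit of > 125000 nM in this assay, at which 4 of the 4 values shown sit. The compounds shown leave open where the true tolerated concentration of each lies, and whether the group on that nitrogen changes it.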